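Replacing 1-benzothiophen-2-yl with 3-methylthiophen-2-yl in a small series

This account rests on a few compounds, and the source may have more. Where it says the series, first, only, none or still open, it means among the compounds named here.

In a functional assay on MGC-803 cells (Homo sapiens) for antiproliferative activity, read by MTT assay, with a stated time of 72 h (a lower number here means a stronger inhibitor, a higher number a weaker inhibitor), compound 3 `O=C(NO)c1ccc(NCc2nc(-c3cc4ccccc4s3)nn2-c2ccccc2)cc1` gives 6110 nM. Compound 2 `O=C(NO)c1ccc(NCc2nc(-c3cccc(Cl)c3)nn2-c2ccccc2)cc1` gives 5760 nM, and the two cannot be told apart, with a 1.1-fold higher number from compound 2 to compound 3 (0.03 log units; within the scatter). Compound 1 `COc1ccc(-c2nc(CNc3ccc(C(=O)NO)cc3)n(-c3ccccc3)n2)cc1` gives > 20000 nM, which is a limit of the assay and not a number.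

Compound 4 `Cc1ccsc1-c1nc(CNc2ccc(C(=O)NO)cc2)n(-c2ccccc2)n1` carries 3-methylthiophen-2-yl in place of 1-benzothiophen-2-yl on an aromatic carbon. Among the measured compounds shown here, all the measured steps fall at this same place. Replacing 4-methoxyphenyl gave an at least 3.4-fold lower number from compound 1 to compound 2 (0.54 log units; beyond the scatter) with 3-chlorophenyl and an at least 3.2-fold lower number from compound 1 to compound 3 (0.51 log units; beyond the scatter) with 1-benzothiophen-2-yl. Two quite different groups thus give matching values in this assay, while compound 1 shows that not every group does. The new group's effect remains unmeasured, so only a small move towards a higher number is expected, possibly none beyond the scatter. The expected step is a 1.3-fold higher number from compound 3 to compound 4 (0.12 log units; within the scatter). Compound 4 is estimated at 8000 nM, with an expected range of 3000 nM to 20000 nM.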

Compound 4, half-maximal inhibitory concentration: 8890 nM
The estimate for compound 4 lay 1.1-fold (0.05 log units) below the measured number, within the range that was stated.
By their numbers in this assay, from the lowest: compounds 2, 3 and 4 (each within the scatter of the next). At a limit, above all of these: compound 1.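

In this assay, the step that removes the six-membered aromatic ring of carbon only from 1-benzothiophen-2-yl and adds a methyl group on a thiophene is small: a 1.5-fold higher number from compound 3 to compound 4 (0.16 log units; within the scatter). The comparison with the monosubstituted phenyl group is just as close, with a 1.5-fold higher number from compound 2 to compound 4 (0.19 log units; within the scatter), so three different groups on this aromatic carbon now cannot be told apart, and the fused six-membered ring is not required for values of this size. Compound 1 remains the exception to this match, with an at least 2.2-fold lower number from compound 1 to compound 4 (0.35 log units; beyond the scatter), and its gap is only a bound set by a limit of the assay: the limit of > 20000 nM in this assay, at which 1 of the 4 values shown sits.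

The compounds shown leave open why 4-methoxyphenyl alone stands apart from the other three groups. They also leave open whether a carboxylic acid, an amine or a simple pyridine ring at this position would give a value distinct from those of compounds 2, 3 and 4.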